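Adding bromo to compound 2: working notes

A few compounds are considered here, and "the series" means these few. Any claim that something is new, unique, unknown or untested is made for them only; others in the source may bear on it.

Measured in a functional assay on MKN-45 cells (Homo sapiens) for cytotoxicity; on this read-out higher numbers stand for weaker inhibition and lower numbers for stronger inhibition:
- compound 1 `COc1ccc(S(=O)(=O)N2CCc3cccc(NC(=O)Oc4ccccc4)c32)cc1`: > 10000 nM (a limit)
- compound 2 `COc1ccc(S(=O)(=O)N2CCc3cccc(NC(=O)c4ccncc4)c32)cc1`: 8.8 nM
- compound 3 `COc1ccc(S(=O)(=O)N2CCc3cccc(NCc4ccccc4)c32)cc1`: > 10000 nM (a limit)

Going by the values given here, compound 2 holds the only actual number in the set (8.8 nM). The other two entries are not numbers (the limit of > 10000 nM in this assay, at which 2 of the 3 values shown sit).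

Compound 4 `COc1ccc(S(=O)(=O)N2CCc3cc(Br)cc(NC(=O)c4ccncc4)c32)cc1` carries bromo in place of hydrogen on an aromatic carbon, meta to the ((pyridin-4-yl)carbonyl)amino group (bromo in place of hydrogen on an aromatic carbon). Among the compounds with values here, no measured step changes this carbon. The two readable steps bear only indirectly: pyridin-4-yl in place of phenoxy gave an at least 1100-fold lower number from compound 1 to compound 2 (3.05 log units; beyond the scatter), and benzyl in place of (pyridin-4-yl)carbonyl gave an at least 1100-fold higher number from compound 2 to compound 3 (3.05 log units; beyond the scatter). Both alter the amino substituent, which compound 4 keeps from compound 2, so a much smaller step is expected in this assay, probably towards a higher number, though the direction is not fixed by the data.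

The expected change is a 2.8-fold higher number from compound 2 to compound 4 (0.45 log units; beyond the scatter). For compound 4 the estimated value is 25 nM, with an expected range of 4 nM to 200 nM.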

Compound 4, half-maximal inhibitory concentration: 86 nM
Beside the measured number, compound 4's estimate is 3.4-fold (0.54 log units) below it, within the range that was stated.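

In this assay, going by these compounds alone, the one change at this aromatic carbon, with the ((pyridin-4-yl)carbonyl)amino group kept, gives a 9.8-fold higher number from compound 2 to compound 4 (0.99 log units; beyond the scatter). This carbon is therefore not indifferent to substitution, although a single bromine atom still leaves compound 4 with a measured value of 86 nM in the nanomolar range. Nothing measured in this set accounts for the size of this step.

With bromo as the only group shown on this carbon, it remains open whether the higher number is specific to bromo or follows from any replacement of hydrogen here, a question that fluoro, methyl or an amine at the same carbon would address. Also open, as far as these compounds go, is whether the step carries over to an amino substituent other than the ((pyridin-4-yl)carbonyl)amino group.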